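Series notes: (1,3-thiazol-2-yl)oxy in place of pyridin-3-yl

The compounds below may be only part of what the source reports. "The series", "measured", "known", "first", "only" and "open" are said of these compounds alone.

Compound 1 `O=C1C(=O)N(Cc2ccc(-c3cccnc3)cc2)c2ccc(OC(F)(F)F)cc21` gives 1600 nM in a functional assay on CHO cells for positive allosteric modulation of muscarinic acetylcholine receptor M5 (Homo sapiens), read by FLIPR and calcium flux, with a stated time of 1 h (on this read-out lower numbers stand for an effect already at smaller amounts and higher numbers for an effect only at larger amounts of compound), and stands at the lowest number of the two measured here. Compound 3 `O=C1C(=O)N(Cc2ccc(-c3ccccc3)cc2F)c2ccc(OC(F)(F)F)cc21` gives 5900 nM in this assay, a step beyond the scatter above compound 1. Compound 2 `O=C1C(=O)N(Cc2cccc(-c3ccccc3)c2)c2ccc(OC(F)(F)F)cc21` reaches only a limit of the assay, > 30000 nM, as recorded in the limit of > 30000 nM in this assay, at which 1 of the 3 values shown sits. Compound 4 `O=C1C(=O)N(Cc2ccc(Oc3nccs3)cc2)c2ccc(OC(F)(F)F)cc21` differs from compound 1 by (1,3-thiazol-2-yl)oxy in place of pyridin-3-yl on an aromatic carbon. For the measured compounds named here, no step between measured compounds covers a change of this kind, so the direction rests on judgement alone. A modest weakening somewhat beyond the scatter is expected, a 2.2-fold higher number from compound 1 to compound 4 (0.34 log units; beyond the scatter). Compound 4 is therefore estimated at 3500 nM in this assay, within 900 nM to 14000 nM.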

Compound 4, half-maximal effective concentration: 2800 nM
Beside the measured number, compound 4's estimate is 1.3-fold (0.10 log units) above it; low and high end bracket the measured number.
By their numbers in this assay, from the lowest: compounds 1 and 4 (each within the scatter of the next); then compound 3. At a limit, above all of these: compound 2.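

In this assay, (1,3-thiazol-2-yl)oxy in place of pyridin-3-yl on this aromatic carbon, para to a large group, gives a 1.8-fold higher number from compound 1 to compound 4 (0.24 log units; within the scatter). This position therefore accepts a five-membered aromatic ring with 2 hetero atoms as well as a six-membered aromatic ring with 1 hetero atom, without a change beyond the scatter. Nothing at hand gives a cause for this step. Still open, going by these compounds, is how an amine, a carboxylic acid or a longer alkyl chain at this position would read in this assay.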